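Anilinopyrimidine series: removing the acetyl from compound 1

The compounds below may be only part of what the source reports. "The series", "measured", "known", "first", "only" and "open" are said of these compounds alone.

Measured in a functional assay for inhibition, with Homo sapiens as the target; a lower number here means a stronger inhibitor, a higher number a weaker inhibitor:
compound 1 `CC(=O)N(C)c1ccc(Nc2nccc(-c3cccnc3)n2)cc1` gives 900 nM
compound 2 `CC(=O)N(C)c1ccc(Nc2nccc(-c3ccncc3)n2)cc1` gives 500 nM

Compound 1 shows the highest of the two numbers in this assay; its nearest neighbour is compound 2, and the step of a 1.8-fold lower number from compound 1 to compound 2 (0.26 log units; within the scatter) lies within the scatter, so the two are not distinguished. That step concerns the pyridinyl attachment and leaves the acetyl(methyl)amino group untouched. Compound 3 `CNc1ccc(Nc2nccc(-c3cccnc3)n2)cc1` differs from compound 1 in one place: hydrogen in place of acetyl on a nitrogen on an aromatic ring. For the measured compounds named here, no measured step touches this part of the molecule, so nothing seen so far indicates the direction or size of the effect; the value of compound 1 in this assay is the only anchor. For compound 3 the expected step is a 1.1-fold higher number from compound 1 to compound 3 (0.05 log units; within the scatter), that is, none beyond the scatter, with a wide range to cover the unknown. For compound 3 the estimated value in this assay is 1000 nM, in the range 300 nM to 4000 nM.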

Compound 3, half-maximal inhibitory concentration: 2100 nM
For compound 3 the middle estimate is 2.1-fold (0.32 log units) below the measured one; measured number inside the range.
By their numbers in this assay, from the lowest: compounds 2 and 1 (each within the scatter of the next); then compound 3.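

In this assay the position on this nitrogen proves responsive: there is a 2.3-fold higher number from compound 1 to compound 3 (0.37 log units; beyond the scatter) when hydrogen replaces acetyl, so acetyl(methyl)amino gives the stronger inhibitor of this pair, by a modest margin. For the compounds shown here, the earlier step between compound 1 and compound 2 concerned only the pyridinyl attachment and stayed within the scatter, so this is the first change that separates two compounds. No available data account for this shift.

From the compounds shown here alone, it remains open whether the effect belongs to the acetyl group as a whole or to its carbonyl, and how a propionyl, a methanesulfonyl or a longer acyl chain on this nitrogen would compare. Also open, going by these compounds, are the effect of the methyl on this nitrogen, as a primary amine would show, and whether the same step holds with the pyridin-4-yl of compound 2.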